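The source may report more compounds than this note shows. Statements on the series, on what has been measured and on what is new or still open speak of the compounds shown alone.

Within the data shown here, compound 3, `Cn1nnnc1SCC(=O)N/N=c1/scc(-c2ccc(C#N)cc2)n1-c1ccccc1`, gives 63.5% in a functional assay on C6 cells (Rattus norvegicus) for cytotoxicity, read by MTT assay, with a stated time of 24 h, tested at 6 ug/mL (on this read-out higher numbers stand for a weaker effect at the one concentration tested and lower numbers for a stronger effect), the lowest of the three numbers so far. Compound 2, `Cn1cnnc1SCC(=O)N/N=c1/scc(-c2ccc(C#N)cc2)n1-c1ccccc1`, gives 70.2%, and the change of a number 6.7 percentage points lower from compound 2 to compound 3 (within the scatter) stays within the scatter. Among the measured compounds shown here, compound 1, `O=C(CSc1nnnn1-c1ccccc1)N/N=c1/scc(-c2ccc(F)cc2)n1-c1ccccc1`, gives 74.9%, a gap to compound 3 that lies beyond the scatter, but no single-place step joins these two, as they also differ on the other aryl ring.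

Compound 4, `N#Cc1ccc(-c2cs/c(=N/NC(=O)CSc3nnnn3-c3ccccc3)n2-c2ccccc2)cc1`, is compound 3 with phenyl in place of methyl on an aromatic nitrogen. For the measured compounds named here, no measured step swaps methyl for phenyl on that nitrogen; the only measured single-place step, a number 6.7 percentage points lower from compound 2 to compound 3 (within the scatter), is a small one at the same part of the molecule. The expected step is therefore a number 4.5 percentage points higher from compound 3 to compound 4 (within the scatter), not beyond the scatter, and compound 4 is estimated at 68%, within 52% to 84%.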

Compound 4, a percentage reported as activity, at one concentration (the size of the read-out at that concentration, not a potency): 78.8%
Compound 4: middle estimate off by 10.8 percentage points, on the low side, within the range that was stated.
By their numbers in this assay, from the lowest: compounds 3, 2, 1 and 4 (each within the scatter of the next, the first and the last beyond it).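

In this assay, phenyl in place of methyl on this aromatic nitrogen gives a number 15.3 percentage points higher from compound 3 to compound 4 (beyond the scatter) and so goes with a weaker effect at the one concentration tested. With phenyl on that nitrogen, cyano in place of fluoro gives a number 3.9 percentage points higher from compound 1 to compound 4 (within the scatter) and 1-phenyl-1H-tetrazol-5-yl in place of 4-methyl-4H-1,2,4-triazol-3-yl gives a number 8.6 percentage points higher from compound 2 to compound 4 (within the scatter) and neither change separates the compounds. Nothing shown explains the size of the phenyl step.

Open, as far as these compounds go, is whether an ethyl or a benzyl on that nitrogen reads like methyl or like phenyl. Also open, from the compounds shown here alone, is how a phenyl carrying an amine or a carboxylic acid would read.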